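This account rests on a few compounds, and the source may have more. Where it says the series, first, only, none or still open, it means among the compounds named here.

Measured compounds:
In a functional assay on Jurkat cells for inhibition of nuclear factor NF-kappa-B complex (Homo sapiens) (a higher number here means a weaker inhibitor, a lower number a stronger inhibitor), compound 1 `CCOC(=O)c1cnc(-c2cc(Cl)nc(Cl)c2)nc1NN1C(=O)C=C(C)C1=O` gives 2000 nM.
In this assay compound 2 `CCOC(=O)c1cnc(-c2cccc(OC)c2)nc1NN1C(=O)C=C(C)C1=O` gives 5000 nM.
In this assay compound 3 `CCOC(=O)c1cnc(-c2ccc(Cl)cc2)nc1NN1C(=O)C=C(C)C1=O` gives 300 nM.

Among these three, compound 1 has the second highest number. Its nearest neighbour is compound 2, reached by a 2.5-fold higher number from compound 1 to compound 2 (0.40 log units; beyond the scatter), and the furthest is compound 3, reached by a 6.7-fold lower number from compound 1 to compound 3 (0.82 log units; beyond the scatter). Compound 4 `CCOC(=O)c1cnc(C2CC2)nc1NN1C(=O)C=C(C)C1=O` has not yet been measured. It differs from compound 1 in one place: cyclopropyl in place of 2,6-dichloropyridin-4-yl on an aromatic carbon. For the measured compounds named here, no measured step makes this kind of change. The three known steps, a 2.5-fold higher number from compound 1 to compound 2 (0.40 log units; beyond the scatter), a 6.7-fold lower number from compound 1 to compound 3 (0.82 log units; beyond the scatter) and a 17-fold lower number from compound 2 to compound 3 (1.22 log units; beyond the scatter), all exchange one six-membered aromatic group for another at the same aromatic carbon of the shared core, and they show that such exchanges can move the number in either direction, by modest to large amounts. Every measured compound carries an aromatic group there, so nothing measured tells what a cyclopropyl group does in that spot. The expectation is therefore uncertain, and the step expected is a 2.5-fold higher number from compound 1 to compound 4 (0.40 log units; beyond the scatter). Compound 4 is estimated at 5000 nM, with a range from 1500 nM to 20000 nM.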

Compound 4, half-maximal inhibitory concentration: 1000 nM
Beside the measured number, compound 4's estimate is 5.0-fold (0.70 log units) above it; measured number below the stated range.
By their numbers in this assay, from the lowest: compound 3; then compounds 4 and 1 (each within the scatter of the next); then compound 2.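

At this aromatic carbon of the shared core, an aromatic ring is not needed for a measurable effect in this assay: the non-aromatic cyclopropyl group of compound 4 stays within the scatter of the 2,6-dichloropyridin-4-yl group of compound 1 (a 2.0-fold lower number from compound 1 to compound 4 (0.30 log units; within the scatter)). Cyclopropyl also sits apart from the two phenyl groups, beating 3-methoxyphenyl (a 5.0-fold lower number from compound 2 to compound 4 (0.70 log units; beyond the scatter)) but falling short of 4-chlorophenyl (a 3.3-fold higher number from compound 3 to compound 4 (0.52 log units; beyond the scatter)), so aromatic groups at this carbon fall on both sides of it, and compound 3 remains the strongest of the four. Nothing at hand explains this ranking.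

Cyclopropyl is the only non-aromatic group shown here, so it remains open whether a longer alkyl chain, a cyclohexyl ring or an amine at this carbon would behave in the same way. An unsubstituted phenyl ring is also absent, which leaves open how much of the result for compound 3 depends on its chlorine.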